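Lengthening the side chain of compound 2

The source may hold more compounds than are shown below. What is called first, only, known or untested is meant among the compounds shown, and "the series" means these compounds.

In a physicochemical assay for lipophilicity, using the shake flask method, measured as octanol-water partition (a lower number here means a more polar compound, a higher number a more lipophilic compound), compound 1 (`Cc1c(C(=O)O)c2ccccn2c1CN`) gives 0.72 as its value, and compound 2 (`CCc1c(C(=O)O)c2ccccn2c1CN`) stands higher with 1.45 as the top of the two numbers. Compound 3 (`CCCCc1c(C(=O)O)c2ccccn2c1CN`) carries ethyl in place of hydrogen on a saturated chain carbon, two bonds along the chain from an aromatic carbon. Among the measured compounds shown here, one measured step bears on this: methyl in place of hydrogen gave a number 0.73 log units higher from compound 1 to compound 2 (beyond the scatter) in that single case. Ethyl is the larger addition, so a bigger rise is expected, with a number 1.15 log units higher from compound 2 to compound 3 (beyond the scatter) as the estimated step. In this assay the expected value for compound 3 is 2.6 (2.1 to 3.1).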

Compound 3, partition coefficient: 2.07
The estimate for compound 3 lay 0.53 log units above the measured number; measured number outside the range, below it.
By their numbers in this assay, from the lowest: compound 1; then compound 2; then compound 3.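

In this assay, among the compounds shown here, the rise goes on as the chain grows: ethyl in place of hydrogen gives a number 0.62 log units higher from compound 2 to compound 3 (beyond the scatter) and the full span reaches a number 1.35 log units higher from compound 1 to compound 3 (beyond the scatter) with no compound going against that order. Yet ethyl, the larger addition, brought no bigger a step than methyl did with a number 0.73 log units higher from compound 1 to compound 2 (beyond the scatter) in the earlier case. No measurement shown gives a reason for this.

Going by these compounds, whether a longer chain would raise the number further or level it off stays open. So does the effect on this number of a chain ending in a hydroxyl or an amine.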